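Bromo for Fluoro Carried onto a Second Core

A few compounds are considered here, and "the series" means these few. Any claim that something is new, unique, unknown or untested is made for them only; others in the source may bear on it.

Measured so far in a functional assay on MCF7 cells (Homo sapiens) for antiproliferative activity, read by MTT assay, with a stated time of 48 h; a higher number here means a weaker inhibitor, a lower number a stronger inhibitor:
Compound 1 `O=C(NS(=O)(=O)c1ccc(F)cc1)c1cncc(Br)c1` gives 980 nM.
Compound 2 `O=C(NS(=O)(=O)c1ccc(Br)cc1)c1cncc(Br)c1` gives 340 nM.
Compound 3 `O=C(NS(=O)(=O)c1ccc(F)cc1)c1ccc(Cl)nc1` gives 16800 nM.

Compound 2 differs from compound 1 by bromo in place of fluoro on an aromatic carbon, and in this assay the pair shows a 2.9-fold lower number from compound 1 to compound 2 (0.46 log units; beyond the scatter). Compound 3 stands on another core; the difference between the core of compound 1 and the core of compound 3 is not broken down here. Its number is the highest of the three, well apart from both compound 1 and compound 2.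

Compound 4 `O=C(NS(=O)(=O)c1ccc(Br)cc1)c1ccc(Cl)nc1` has not been measured. It differs from compound 3 by bromo in place of fluoro on an aromatic carbon, and the place of this change reads the same, word for word, as for the change from compound 1 to compound 2, so it is the same change applied to the core of compound 3. In this assay, for the measured compounds named here, the step from compound 3 to compound 4 is expected to be a 2.6-fold lower number from compound 3 to compound 4 (0.41 log units; beyond the scatter), close in size to a 2.9-fold lower number from compound 1 to compound 2 (0.46 log units; beyond the scatter), which is the only measured example of this change and therefore a thin basis. Compound 4 is accordingly expected to give 6500 nM, with a range from 2500 nM to 17000 nM.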

Compound 4, half-maximal inhibitory concentration: 9050 nM
Beside the measured number, compound 4's estimate is 1.4-fold (0.14 log units) below it; the measured number falls inside the stated range.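

In this assay the replacement of fluoro by bromo on the core of compound 3 gives a 1.9-fold lower number from compound 3 to compound 4 (0.27 log units; within the scatter) and so does not separate the two compounds beyond the usual scatter. Set beside the earlier step, the change reads alike on the two cores, with no difference between the steps that the data can resolve: the same change on two cores in this assay, a 2.9-fold lower number (0.46 log units; beyond the scatter) from compound 1 to compound 2 and a 1.9-fold lower number (0.27 log units; within the scatter) from compound 3 to compound 4, 1.6-fold (0.19 log units) apart, within the scatter of two such steps. This does not establish that the change carries over as a rule, as only two cores are shown, only the step on the first core lies beyond the scatter, and agreement within the scatter does not prove that the two steps are equal.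

The compounds shown leave open whether iodo, methyl or methoxy at the same place would follow the same course, and whether an amine or a carboxylic acid there would be tolerated. They also leave open whether the step between bromo and fluoro would hold on a third core.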